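Replacing a tetrazole with a tert-butoxycarbonyl ester

The source may report more compounds than this note shows. Statements on the series, on what has been measured and on what is new or still open speak of the compounds shown alone.

Compound 1 `CCn1nnc(-c2ccc(NC(=O)CSc3nnc(CNc4ccccc4)n3CC)cc2)n1` was tested in an assay on isolated protein for inhibition of long-chain fatty acid transport protein 1 (Mus musculus) (on this read-out lower numbers stand for stronger inhibition and higher numbers for weaker inhibition), and returned only a limit, > 10000 nM (the limit of > 10000 nM in this assay, at which 1 of the 3 values shown sits), so no number is known for it. Two related compounds share the same core. Compound 2 `CCc1ccc2oc(CSc3nnc(CNc4ccccc4)n3CC)nc2c1` gives 1800 nM in this assay, and compound 3 `CCn1c(CNc2ccccc2)nnc1SCc1nc2cc(OC(F)(F)F)ccc2o1` gives 91 nM. Within the data shown here, the one step measured between them, a 20-fold lower number from compound 2 to compound 3 (1.30 log units; beyond the scatter), concerns a change on a different part of the molecule from the one now in question.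

Compound 4 `CCn1c(CNc2ccccc2)nnc1SCC(=O)Nc1ccc(C(=O)OC(C)(C)C)cc1` differs from compound 1 in a single place: tert-butoxycarbonyl in place of 2-ethyl-2H-tetrazol-5-yl on an aromatic carbon. Among the measured compounds shown here, no measured step follows this kind of exchange, a change in the group on the outer aromatic ring of the amide side, so the step from compound 2 to compound 3 offers no direct guide to its size or direction. For the measured compounds named here, the only anchor is that compound 1 sits at the limit of this assay, and the shared core with the anilinomethyl-triazole thioether is kept.

On that basis compound 4 is expected to remain weak in this assay, with an estimated value of 8000 nM and a range from 1500 nM to 30000 nM. The step from compound 1 to compound 4 is expected to be an at least 1.2-fold lower number from compound 1 to compound 4 (0.09 log units; that floor lies within the scatter), which cannot be judged against a limit.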

Compound 4, half-maximal inhibitory concentration: > 10000 nM
Compound 4 was reported as a limit (the forecaster's own chance of this, stated with the estimate: 50%); middle value at least 1.2-fold (0.09 log units) away from the limit.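

Compound 4 also returned only a limit in this assay, > 10000 nM, as compound 1 did, so no step can be read between compound 1 and compound 4: the limit of > 10000 nM in this assay, at which 2 of the 4 values shown sit.

The compounds shown leave open how far either compound lies from that limit, and whether tert-butoxycarbonyl in place of 2-ethyl-2H-tetrazol-5-yl changes inhibition at all.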